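Morpholine Amide to Methylamide: Expected Inhibition of Compound 4

A few compounds are considered here, and "the series" means these few. Any claim that something is new, unique, unknown or untested is made for them only; others in the source may bear on it.

Measured in an assay on a protein complex for inhibition of CDK8/Cyclin C (Homo sapiens), with a stated time of 1 h, tested at 10 uM; on this read-out lower numbers stand for less inhibition and higher numbers for more inhibition at the one concentration tested (going by the name of the read-out):
compound 1 `CNC(=O)/C=C/c1ccncc1-c1ccc2cc[nH]c2c1` gives 103%
compound 2 `O=C(/C=C/c1ccncc1-c1ccc2cc[nH]c2c1)N1CCOCC1` gives 102%
compound 3 `O=C(CCc1ccncc1-c1ccc2ccccc2c1)N1CCOCC1` gives 100%

All three numbers lie within the scatter of one another. The change methylamino in place of morpholin-4-yl on a carbonyl carbon gives the step of a number 1 percentage points higher from compound 2 to compound 1 (within the scatter). Compound 4 `CNC(=O)CCc1ccncc1-c1ccc2ccccc2c1` is not yet measured; it arises from compound 3 by methylamino in place of morpholin-4-yl on a carbonyl carbon. This is the same kind of change, but the place differs: in compound 2 the carbonyl carbon's other neighbour is a double-bonded chain carbon, in compound 3 a saturated chain carbon. The difference between the cores of compound 2 and compound 3 is not broken down here. Since compound 3 gives 100% and the earlier step was a number 1 percentage points higher from compound 2 to compound 1 (within the scatter), compound 4 is expected to show a step of about no change at the digits printed from compound 3 to compound 4 (within the scatter). Compound 4 is estimated at 100%, between 92% and 106%.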

Compound 4, a percentage reported as inhibition, at one concentration (the size of the read-out at that concentration, not a potency): 100%
Compound 4: middle estimate and measured number agree at the digits printed, and the stated range covers the measured number.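

In this assay, methylamino in place of morpholin-4-yl on a carbonyl carbon gives no change at the digits printed from compound 3 to compound 4 (within the scatter). Set beside the same change on the other core, the two steps agree: the same change on two cores in this assay, a number 1 percentage points higher (within the scatter) from compound 2 to compound 1 and no change at the digits printed (within the scatter) from compound 3 to compound 4, 1 percentage points apart, within the scatter of two such steps. Across these two pairs the change therefore carries from one core to the other without a visible difference, but this read-out comes from a single concentration and is not a potency, so it cannot show whether potency shifts with the change.

The compounds shown leave open how a dimethylamino group or a carboxylic acid on the same carbonyl carbon would read. They also leave open whether the two steps would still agree at a lower concentration.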